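This account rests on a few compounds, and the source may have more. Where it says the series, first, only, none or still open, it means among the compounds named here.

Measured so far:
- compound 1 `Cc1c(OCCCCOc2ccc(C(=O)O)cc2Cl)ccc(C(=O)CC2CCCC2)c1O`: 120%
- compound 2 `Cc1c(OCCCCOc2ccc(F)c(C(=O)O)c2)ccc(C(=O)CC(C)(C)C)c1O`: 83%
- compound 3 `Cc1c(OCCCCOc2ccc(C(=O)O)cc2Cl)ccc(C(=O)CC(C)C)c1O`: 123%

In an ADME assay on a cell-free system (plasma, Rattus norvegicus) for metabolic stability, read by LC-MS, with a stated time of 60 min, tested at 100 uM (on this read-out lower numbers stand for a less stable compound and higher numbers for a more stable compound), compound 1 gives 120%. That is level with compound 3 within the scatter, while compound 2 lies clearly lower.

Compound 4 `Cc1ccc(C(=O)O)cc1OCCCCOc1ccc(C(=O)CC2CCCC2)c(O)c1C` differs from compound 1 in one place: 5-carboxy-2-methylphenyl in place of 4-carboxy-2-chlorophenyl on an oxygen on a saturated carbon. It has 5-carboxy-2-methylphenyl in place of 4-carboxy-2-chlorophenyl on an oxygen on a saturated carbon.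

Among the compounds with values here, the only measured single change is a number 3 percentage points higher from compound 1 to compound 3 (within the scatter). It swaps isopropyl for cyclopentyl at the other end of the molecule, so it says little about this aryl group. Within the data shown here, no measured step isolates this aryl change. Differing from compound 1 in more than one place, including the aryl group, compound 2 stands at 83%. That value shows that a clearly lower number can occur in this family, so a moderate fall seems more likely than a rise.

The expected change is a number 20 percentage points lower from compound 1 to compound 4 (beyond the scatter), which is only a tentative estimate. Compound 4 is estimated at 100%, within an expected range from 78% to 122%.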

Compound 4, percent of the compound remaining: 100%
The estimate for compound 4 equals the measured number at the digits printed; low and high end bracket the measured number.
By their numbers in this assay, from the lowest: compound 2; then compound 4; then compounds 1 and 3 (each within the scatter of the next).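

In this assay, within the data shown here, the first single change at the aryl end of the molecule, 5-carboxy-2-methylphenyl in place of 4-carboxy-2-chlorophenyl on an oxygen on a saturated carbon, gives a number 20 percentage points lower from compound 1 to compound 4 (beyond the scatter). Among these compounds, the read-out therefore responds to this aryl group, whereas the one change measured at the other end of the molecule gives a number 3 percentage points higher from compound 1 to compound 3 (within the scatter). This single swap alters both the carboxy placement and the chloro and methyl substituents at once, and no measurement here explains the shift.

The compounds shown leave open which of those two alterations accounts for the step, a question that 4-carboxy-2-methylphenyl on the same oxygen could help separate. They also leave open how an amide in place of the carboxylic acid would read in this assay.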